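The source may report more compounds than this note shows. Statements on the series, on what has been measured and on what is new or still open speak of the compounds shown alone.

Measured in an ADME assay on microsomes from liver (Rattus norvegicus) for metabolic stability; a higher number here means faster removal of the compound, a lower number slower removal:
- compound 1 `CNc1nc(NC2(C#N)CCCCC2)nc(-n2cncn2)n1`: 52 mL/min/kg
- compound 2 `CNc1nc(NC2(C#N)CCCCC2)nc(N(C)C)n1`: 276 mL/min/kg

Compound 2 stands at 276 mL/min/kg, the higher of the two numbers, so it is the faster removed. The next structure, compound 3 `CNc1nc(NC2(C#N)CCCCC2)nc(OC)n1`, keeps the shared core and has methoxy in place of dimethylamino on an aromatic carbon. Among the measured compounds shown here, only one measured step bears on this, because it changes the same place: a 5.3-fold higher number from compound 1 to compound 2 (0.72 log units; beyond the scatter). That step is modest but beyond the scatter, so a swap here can clearly move the number. For the measured compounds named here, no measured compound yet shows what methoxy itself does, and the forecast is therefore loose. With compound 2 at the top of the two numbers, a fall is more likely than a rise. The expected change is a 2.1-fold lower number from compound 2 to compound 3 (0.33 log units; beyond the scatter). For compound 3 the estimated clearance is 130 mL/min/kg, within an expected range of 55 mL/min/kg to 300 mL/min/kg.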

Compound 3, clearance: 196 mL/min/kg
The estimate for compound 3 lay 1.5-fold (0.18 log units) below the measured number; the range from low to high includes it.
By their numbers in this assay, from the lowest: compound 1; then compounds 3 and 2 (each within the scatter of the next).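

In this assay, methoxy in place of dimethylamino gives a 1.4-fold lower number from compound 2 to compound 3 (0.15 log units; within the scatter), so at this position the two groups cannot be told apart, although an oxygen now replaces a nitrogen on the ring carbon. Methoxy in place of 1H-1,2,4-triazol-1-yl gives a 3.8-fold higher number from compound 1 to compound 3 (0.58 log units; beyond the scatter), so the gap first seen with dimethylamino also appears with a second, different group, and compound 1 is the only one of the three set apart from the others. No measurement available here explains this difference.

From the compounds shown here alone, it remains open whether slower removal needs this particular triazole or would also appear with another ring, such as pyrazole or imidazole. Going by these compounds, how a longer ether chain such as ethoxy, or a cyclic amine such as morpholine, would compare at this position also remains open.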